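The compounds below may be only part of what the source reports. "The series", "measured", "known", "first", "only" and "open" are said of these compounds alone.

Measured compounds:
compound 1 `CCOCC(=O)OCCc1c(-c2ccccc2Cl)c2cc(Cl)ccc2[nH]c1=O` with 130000 nM
compound 2 `O=C(CCC1CCCCC1)OCCc1c(-c2ccccc2Cl)c2cc(Cl)ccc2[nH]c1=O` with 160000 nM
compound 3 `O=C(OCCc1c(-c2ccccc2Cl)c2cc(Cl)ccc2[nH]c1=O)c1ccc([N+](=O)[O-])cc1` with 1600000 nM

These three compounds share one core and differ only in the ester group attached to it. In an ADME assay on HepG2 2.2.15 cells (Homo sapiens) for cytotoxicity (a higher number here means that more compound is tolerated, a lower number that less compound is tolerated), compound 1 gives the lowest of the three numbers. Its nearest neighbour is compound 2, a 1.2-fold higher number from compound 1 to compound 2 (0.09 log units; within the scatter). Its furthest is compound 3, a 12-fold higher number from compound 1 to compound 3 (1.09 log units; beyond the scatter). The step of a 10-fold higher number from compound 2 to compound 3 (1.00 log units; beyond the scatter) points the same way, so among these three the one compound carrying an aromatic ring on the carbonyl carbon is tolerated at a clearly higher concentration than either compound with a saturated chain there.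

Compound 4 `COc1ccc(/C=C/C(=O)OCCc2c(-c3ccccc3Cl)c3cc(Cl)ccc3[nH]c2=O)cc1OC` is not yet measured. It differs from compound 1 as follows: 2-(3,4-dimethoxyphenyl)ethenyl in place of ethoxymethyl on a carbonyl carbon. Like compound 3, it places an aromatic ring on the ester carbonyl side, though separated from the carbonyl carbon by a double bond. The steps from compound 1 to compound 3 and from compound 2 to compound 3 are the ones that bear on this change, and both were beyond the scatter and upward. The step from compound 1 to compound 4 is therefore expected to be upward, a 3.8-fold higher number from compound 1 to compound 4 (0.59 log units; beyond the scatter), with considerable uncertainty because the new group is larger and not the same as that of compound 3. For compound 4 the estimated value in this assay is 500000 nM, within a range from 150000 nM to 1600000 nM.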

Compound 4, half-maximal cytotoxic concentration: > 1200000 nM
Compound 4 gave a limit, no number; the forecaster's own chance of this, stated with the estimate: 20%; at least 2.4-fold (0.38 log units) between middle value and limit.
By their numbers in this assay, from the lowest: compounds 1 and 2 (each within the scatter of the next); then compound 3.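

In this assay compound 4 does not give a number, only a limit: the limit of > 1200000 nM in this assay, at which 1 of the 4 values shown sits.

Even this limit can be read against the saturated esters, giving an at least 9.2-fold higher number from compound 1 to compound 4 (0.96 log units; beyond the scatter) and an at least 7.5-fold higher number from compound 2 to compound 4 (0.87 log units; beyond the scatter). Compound 3 alone could not show that the upward shift goes beyond a single group, whereas here a second aromatic group, 2-(3,4-dimethoxyphenyl)ethenyl, also stands clearly above both compounds with a saturated chain on the carbonyl carbon, even with a double bond outside the aromatic ring in the group, and none of the four compounds goes against this pattern.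

On these data alone, the step between compound 3 and compound 4 cannot be read, so the order of those two remains unknown. It also remains open whether the aromatic ring itself goes with the higher numbers, as the compounds shown do not include a plain phenyl group, a saturated ring such as cyclohexyl bound directly to the carbonyl carbon, or a chain ending in an amine or a carboxylic acid.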